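The compounds below may be only part of what the source reports. "The series", "measured", "known", "first", "only" and "open" are said of these compounds alone.

The series shares the core of compound 1 `COc1cc2c(Nc3ccc(C#N)cc3)ncnc2cc1OCCCN(C)C`, which in a functional assay on SH-SY5Y cells (Homo sapiens) for antiproliferative activity, read by MTT assay, with a stated time of 72 h (a lower number here means a stronger inhibitor, a higher number a weaker inhibitor), gives 34900 nM. Compound 2 `CCN(CC)CCCOc1cc2ncnc(Nc3ccc(C#N)cc3)c2cc1OC` carries a diethylamino group where compound 1 has dimethylamino. In this assay compound 2 reaches only > 100000 nM, which is a limit of the assay rather than a number. The step of an at least 2.8-fold higher number from compound 1 to compound 2 (0.45 log units; beyond the scatter) is accordingly known only as a floor, set by the limit of > 100000 nM in this assay, at which 1 of the 2 values shown sits. Compound 3 `COc1cc2c(Nc3ccc(C#N)cc3)ncnc2cc1OCCCN(C)Cc1ccccc1` differs from compound 2 in one place: benzyl(methyl)amino in place of diethylamino on a saturated chain carbon, three bonds along the chain from an oxygen on an aromatic ring. For the measured compounds named here, the single measured step that bears on this change is the one from compound 1 to compound 2, in which the larger amine went with the weaker inhibitor; the present change enlarges the amine further. The expected step is a step that the limit leaves unreadable from compound 2 to compound 3, meaning no gain and most probably a value that again sits at the limit. Compound 3 is therefore expected to give about 150000 nM, within 50000 nM to 450000 nM.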

Compound 3, half-maximal inhibitory concentration: > 100000 nM
Compound 3 gave a limit, no number; the forecaster's own chance of this, stated with the estimate: 75%; the middle value is on the limit's open side.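

In this assay, the change at this place adds a second enlarged amine on the weak side of compound 1: with phenyl in place of hydrogen on a saturated chain carbon bound to an amine nitrogen, the result is an at least 2.8-fold higher number from compound 1 to compound 3 (0.45 log units; beyond the scatter). The loss seen with diethylamino is therefore also found with benzyl(methyl)amino, which carries a six-membered aromatic ring, though across these compounds only dimethylamino gives a readable number. The step between compound 2 and compound 3 cannot be read: the limit of > 100000 nM in this assay, at which 2 of the 3 values shown sit.

Going by these compounds, how far compound 2 and compound 3 lie past this limit remains open, and so does any order between them. Also open, on these data alone, is whether a smaller amine such as methylamino, a morpholine or a longer chain would give a stronger inhibitor than compound 1.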